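The source may report more compounds than this note shows. Statements on the series, on what has been measured and on what is new or still open speak of the compounds shown alone.

Two compounds of the series have readings in an ADME assay on the whole organism (Macaca fascicularis) for pharmacokinetics, read by LC-MS, using cassette dosing, at a dose of 1 mg/kg by the oral route; on this read-out higher numbers stand for higher exposure at the dose given and lower numbers for lower exposure. Compound 1 `C[C@H](c1ccc(-c2ccccc2-c2nc(=O)o[nH]2)cc1)N(CC1CC1)c1nc2c(C(=O)O)cccc2o1` gives 7710 nM in this assay. Among the measured compounds shown here, compound 2 `CCCCN(c1nc2c(C(=O)O)cccc2o1)[C@H](C)c1ccc(-c2cc(F)ccc2-c2nc(=O)o[nH]2)cc1` gives 1180 nM in this assay, the lowest of the two numbers, with compound 1 the only neighbour and its number beyond the scatter above that of compound 2. For the measured compounds named here, no single-point step between measured compounds is available, so the two values can only be set side by side.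

Compound 3 `C[C@H](c1ccc(-c2cc(F)ccc2-c2nc(=O)o[nH]2)cc1)N(CC1CC1)c1nc2c(C(=O)O)cccc2o1` is not yet measured. It differs from compound 2 by cyclopropyl in place of propyl on a saturated chain carbon bound to a nitrogen on an aromatic ring. The chain that enters in compound 3 is the one carried by compound 1, whose value in this assay is the higher of the two shown, while the fluorine of compound 2 is kept. For compound 3 a moderate rise is expected, a 2.5-fold higher number from compound 2 to compound 3 (0.41 log units; beyond the scatter), beyond the scatter but not reaching the number of compound 1. The estimate for compound 3 in this assay is 3000 nM, with a range from 1000 nM to 9000 nM.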

Compound 3, maximal plasma concentration: 2900 nM
Beside the measured number, compound 3's estimate is 1.0-fold (0.01 log units) above it, and the stated range covers the measured number.
By their numbers in this assay, from the lowest: compound 2; then compound 3; then compound 1.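

In this assay, among the compounds shown here, with the fluorine kept, cyclopropyl in place of propyl on a saturated chain carbon bound to a nitrogen on an aromatic ring gives a 2.5-fold higher number from compound 2 to compound 3 (0.39 log units; beyond the scatter) as the first reading of this chain change on its own. With the cyclopropyl kept, fluoro in place of hydrogen on an aromatic carbon gives a 2.7-fold lower number from compound 1 to compound 3 (0.42 log units; beyond the scatter) and so shows that the gap between the two earlier compounds is not carried by the chain alone, since both single changes give modest steps beyond the scatter. Nothing shown gives a reason for either step.

Still open, from the compounds shown here alone, is whether the chain step holds with hydrogen in place of the fluoro. Also open, going by these compounds, is how a cyclobutyl group, a longer chain or a chloro in place of the fluoro would read.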